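Swapping one substituted phenyl for another on the core

This account rests on a few compounds, and the source may have more. Where it says the series, first, only, none or still open, it means among the compounds named here.

Two compounds share a core and differ only in one aromatic group hanging from a double-bonded chain carbon. Compound 1 `CC/C(=C(/c1ccc(/C=C/C(=O)O)cc1)c1cc2ccccc2[nH]1)c1ccccc1Cl` carries a chloro on that aromatic ring, and in a functional assay on MCF7 cells (Homo sapiens) for inhibition (on this read-out lower numbers stand for stronger inhibition and higher numbers for weaker inhibition), compound 1 gives 42 nM. Compound 2 `CC/C(=C(/c1ccc(/C=C/C(=O)O)cc1)c1cc2ccccc2[nH]1)c1ccccc1C(F)(F)F` carries a trifluoromethyl there instead, and in this assay compound 2 gives 8 nM. The change gave a 5.3-fold lower number from compound 1 to compound 2 (0.72 log units; beyond the scatter), so compound 2 stands at the lower of the two numbers.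

Compound 3 `CC/C(=C(/c1ccc(/C=C/C(=O)O)cc1)c1cc2ccccc2[nH]1)c1ccc(Cl)cc1Cl` has not been measured. It differs from compound 2 by 2,4-dichlorophenyl in place of 2-(trifluoromethyl)phenyl on a double-bonded chain carbon bound to a double-bonded chain carbon and a saturated chain carbon. Going by the values given here, only one measured step bears on this: the step from compound 1 to compound 2, which shows that a chloro in place of a trifluoromethyl on this ring sits at the higher number. Compound 3 returns to a chloro and adds a second one, for which no comparison exists. The number for compound 3 is therefore expected to rise, roughly reversing that step, by a 3.8-fold higher number from compound 2 to compound 3 (0.57 log units; beyond the scatter). Compound 3 is estimated at 30 nM, within 10 nM to 90 nM.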

Compound 3, half-maximal inhibitory concentration: 11 nM
Beside the measured number, compound 3's estimate is 2.7-fold (0.44 log units) above it; low and high end bracket the measured number.
By their numbers in this assay, from the lowest: compounds 2 and 3 (each within the scatter of the next); then compound 1.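

Adding a second chloro to the ring of compound 1, which turns it into 2,4-dichlorophenyl, gives a 3.8-fold lower number from compound 1 to compound 3 (0.58 log units; beyond the scatter) in this assay, the first sign that a further group on this ring can change the number. Going by these compounds alone, exchanging 2-(trifluoromethyl)phenyl for 2,4-dichlorophenyl gives a 1.4-fold higher number from compound 2 to compound 3 (0.14 log units; within the scatter) and so leaves the two compounds indistinguishable in this read-out, which means a trifluoromethyl is not the only group on this ring that can match the number of compound 2: the gap between the single chloro and the trifluoromethyl closes once a second chloro is present. Nothing in the data explains why these groups compare as they do.

The compounds shown leave open whether a methoxy, an amine or a nitrile in place of the second chloro would keep the number as low as that of compound 3. From the compounds shown here alone, it also remains open whether a second group such as a chloro, added to the ring of compound 2, would lower its number further or leave it unchanged.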